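From a Naphthalene to a Difluorophenyl Group

The source may hold more compounds than are shown below. What is called first, only, known or untested is meant among the compounds shown, and "the series" means these compounds.

Going by the values given here, compound 2 `O=C(O)C1=Cc2ccccc2OC1(OCc1cc(-c2ccc3ccccc3c2)no1)C(F)(F)F` gives 141000 nM in a functional assay on DU-145 cells (Homo sapiens) for inhibition, read by MTT assay, with a stated time of 24 h (a higher number here means a weaker inhibitor, a lower number a stronger inhibitor), one of only two numbers measured so far. Compound 1 `O=C(O)C1=Cc2ccccc2OC1(OCc1cc(-c2ccc([N+](=O)[O-])cc2)no1)C(F)(F)F` gives 100000 nM in this assay, and the step of a 1.4-fold higher number from compound 1 to compound 2 (0.15 log units; within the scatter) shows the two sit within the scatter of each other. The move to compound 3 `O=C(O)C1=Cc2ccccc2OC1(OCc1cc(-c2ccc(F)cc2F)no1)C(F)(F)F` is 2,4-difluorophenyl in place of naphthalen-2-yl on an aromatic carbon. Among the compounds with values here, the only measured step touching this position is the one from compound 1 to compound 2, and it stayed within the scatter, so for compound 3 no shift beyond the scatter is expected in this assay, giving an expected step of a 1.2-fold lower number from compound 2 to compound 3 (0.07 log units; within the scatter). Compound 3 is therefore estimated at 120000 nM, with a range from 40000 nM to 350000 nM.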

Compound 3, half-maximal inhibitory concentration: > 150000 nM
Compound 3: no number, only a limit; the forecaster's own chance of this, stated with the estimate: 25%; at least 1.2-fold (0.09 log units) between middle value and limit.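

For compound 3 the result in this assay is a limit, not a number: the limit of > 150000 nM in this assay, at which 1 of the 3 values shown sits.

Read from that limit, the steps are an at least 1.0-fold higher number from compound 2 to compound 3 (0.02 log units; that floor lies within the scatter) and an at least 1.5-fold higher number from compound 1 to compound 3 (0.17 log units; that floor lies within the scatter). Going by these compounds alone, both floors lie within the scatter, so their true size stays unknown, but exchanging the two rings of naphthalen-2-yl for the single ring of 2,4-difluorophenyl gave no step towards a stronger inhibitor.

On these data alone, how far compound 3 lies past its limit remains open. So does whether an amine or a longer alkyl chain on this aromatic carbon would give a lower number.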